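Trimming one methoxy group on a shared core

A few compounds are considered here, and "the series" means these few. Any claim that something is new, unique, unknown or untested is made for them only; others in the source may bear on it.

Compound 1 `COc1ccc(-c2cc(/C=C/C(=O)c3ccc(N)cc3)[nH]n2)cc1` in a functional assay on MDA-MB-468 cells (Homo sapiens) for cytotoxicity, read by sulforhodamine B assay, with a stated time of 48 h, tested at 0.1 uM; a lower number here means a stronger effect, a higher number a weaker effect of the compound at the concentration tested: 86%
Compound 2 `COc1cc(-c2cc(/C=C/C(=O)c3ccc(N)cc3)[nH]n2)cc(OC)c1OC` in this assay: 83%

Both measured compounds share the same core and differ only in the number of methoxy groups on one aromatic ring. In this assay compound 2 and compound 1 sit within the usual scatter of each other, so the two cannot be told apart on these numbers; both leave most of the cell signal intact at the concentration tested.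

Compound 3 `COc1ccc(-c2cc(/C=C/C(=O)c3ccc(N)cc3)[nH]n2)cc1OC` takes the change (hydrogen in place of methoxy on an aromatic carbon). Among the compounds with values here, with no measured pair of this kind to lean on, the expectation rests on the two values in hand: one methoxy group and three methoxy groups give much the same read-out, so a ring carrying two is expected to fall in the same band. The step of a number 2 percentage points higher from compound 2 to compound 3 (within the scatter) is therefore expected to be none beyond the scatter. In this assay compound 3 is estimated at 85%, with a range from 72% to 98%.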

Compound 3, a percentage reported as activity, at one concentration (the size of the read-out at that concentration, not a potency): 91%
Beside the measured number, compound 3's estimate is 6 percentage points below it; the measured number falls inside the stated range.
By their numbers in this assay, from the lowest: compounds 2, 1 and 3 (each within the scatter of the next).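

In this assay, putting hydrogen in place of a methoxy group on this aromatic carbon gives a number 8 percentage points higher from compound 2 to compound 3 (within the scatter) and putting methoxy in place of hydrogen on the ring gives a number 5 percentage points higher from compound 1 to compound 3 (within the scatter) so the change has now been seen from both sides of the same ring. Both steps stay inside the usual spread of repeated measurements, which means that rings carrying one, two or three methoxy groups cannot be told apart here, and that this position shows no sensitivity to the swap at the single concentration tested. No independent measurement is available to explain this flat result.

On these data alone, what remains open is whether a group of a different kind on this aromatic carbon, such as a hydroxyl group, a fluorine atom or a longer ethoxy chain, would move the read-out beyond the scatter. As far as these compounds go, it is also open whether a ring with no methoxy group at all would differ, or whether a higher concentration would separate these three compounds.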